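A few compounds are considered here, and "the series" means these few. Any claim that something is new, unique, unknown or untested is made for them only; others in the source may bear on it.

Compound 1 `C=C[C@@](C)(O)CC[C@H]1C(=C)CC[C@@H]2[C@]1(C)CCC[C@]2(C)C(=O)O` is a diterpenoid acid carrying a short oxygen-bearing side chain on its core. In a functional assay on SMMC-7721 cells (Homo sapiens) for cytotoxicity, read by MTT assay, with a stated time of 48 h (on this read-out higher numbers stand for weaker inhibition and lower numbers for stronger inhibition), compound 1 gives > 40000 nM, and this is a limit of the assay rather than a measured number. Compound 2 `C=C1CC[C@@H]2[C@](C)(CCC[C@@]2(C)C(=O)O)[C@H]1CC/C(C)=C/COC(C)=O` keeps the same core with a different side chain. In this assay compound 2 gives > 40000 nM, which is likewise a limit and not a number. Where compound 1 stands is thus fixed only by the limit of > 40000 nM in this assay, at which 2 of the 2 values shown sit; the two values show no difference between them, and no measured step between these compounds can be drawn.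

Compound 3 `C=CC(=C)[C@H](O)C[C@H]1C(=C)CC[C@@H]2[C@]1(C)CCC[C@]2(C)C(=O)O` is the compound still to be tested. It differs from compound 1 by a group of 6 heavy atoms (5 carbon, 1 oxygen; no ring) in place of a group of 6 heavy atoms (5 carbon, 1 oxygen; no ring), on a saturated chain carbon bound to a saturated ring carbon. Since compound 1 sits at the limit, with > 40000 nM, a change to the chain of the same size offers no measured basis for a step, and the expected step from compound 1 to compound 3 in this assay is a number no higher from compound 1 to compound 3 (the limit leaves the size open), none beyond the scatter. Compound 3 is accordingly expected to give 40000 nM in this assay, within a range from 15000 nM to 100000 nM.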

Compound 3, half-maximal inhibitory concentration: > 40000 nM
Compound 3: no number, only a limit (the forecaster's own chance of this, stated with the estimate: 70%); the middle value sits exactly at the limit.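

In this assay compound 3 gives > 40000 nM, which is a limit and not a number. Within the data shown here, compound 1 also sits at a limit there, so no step from compound 1 to compound 3 can be read. The compounds shown leave open whether changing the side chain alters cytotoxicity at all, as all that is available is: the limit of > 40000 nM in this assay, at which 3 of the 3 values shown sit.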